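The compounds below may be only part of what the source reports. "The series", "measured", "known", "first", "only" and "open" are said of these compounds alone.

Compound 1 `O=C(Nc1cc(Sc2ncn[nH]2)c(O)c2ccccc12)c1ccc([N+](=O)[O-])cc1` gives only a limit of the assay, > 100000 nM.
Compound 2 `O=C(Nc1cc(Sc2ncn[nH]2)c(O)c2ccccc12)c1cccc([N+](=O)[O-])c1` gives 70200 nM.
Compound 3 `O=C(Nc1cc(Sc2ncn[nH]2)c(O)c2ccccc12)c1ccc2ccccc2c1` gives only a limit of the assay, > 100000 nM.

In a functional assay on HCT-116 cells (Homo sapiens) for antiproliferative activity, read by MTT assay, with a stated time of 48 h (a lower number here means a stronger inhibitor, a higher number a weaker inhibitor), compound 3 stands at a limit rather than a number, namely (the limit of > 100000 nM in this assay, at which 2 of the 3 values shown sit). Compound 4 `O=C(Nc1cc(Sc2ncn[nH]2)c(O)c2ccccc12)c1cccc(Cl)c1` differs from it by 3-chlorophenyl in place of naphthalen-2-yl on a carbonyl carbon. Within the data shown here, two measured steps touch this change: an at least 1.4-fold higher number from compound 2 to compound 3 (0.15 log units; that floor lies within the scatter), and a step that the two limits leave unreadable from compound 1 to compound 3. Compound 4 carries a 3-chlorophenyl, which resembles the 3-nitrophenyl of compound 2, and compound 2 gives 70200 nM. For compound 4 a number rather than the limit seen for compound 3 is therefore expected, though the scatter leaves the size uncertain. Compound 4 is therefore estimated at 60000 nM, within 20000 nM to 150000 nM. That would mean an expected at least 1.6-fold lower number from compound 3 to compound 4 (0.22 log units; that floor lies within the scatter).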

Compound 4, half-maximal inhibitory concentration: > 100000 nM
Compound 4: no number, only a limit (the forecaster's own chance of this, stated with the estimate: 40%); middle value at least 1.6-fold (0.22 log units) from the limit.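

In this assay, chloro in place of nitro on an aromatic carbon gives an at least 1.4-fold higher number from compound 2 to compound 4 (0.15 log units; that floor lies within the scatter). The steps from compound 1 and compound 3 to compound 4 cannot be read, so a single aromatic ring with 3-chlorophenyl cannot be told apart from naphthalen-2-yl here. Compound 2 is now the only compound shown that gives a number rather than the limit: the limit of > 100000 nM in this assay, at which 3 of the 4 values shown sit.

On these data alone, it remains open whether an amine or a carboxylic acid in place of nitro on that aromatic carbon would give a number, and how far below the limit any such compound would fall.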